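Aryl swaps on the triazole series: compound 3 to compound 4

This account rests on a few compounds, and the source may have more. Where it says the series, first, only, none or still open, it means among the compounds named here.

- compound 1 `C=C1CCC[C@]2(C)CCC(c3cn(-c4ccc(OC)cc4)nn3)=CC[C@@]12C` gives 410000 nM
- compound 2 `C=C1CCC[C@]2(C)CCC(c3cn(-c4cccc([N+](=O)[O-])c4)nn3)=CC[C@@]12C` gives 699000 nM
- compound 3 `C=C1CCC[C@]2(C)CCC(c3cn(-c4cccc(OC)c4)nn3)=CC[C@@]12C` gives 734000 nM

All three values come from an ADME assay on HEK293 cells (Homo sapiens) for cytotoxicity, read by MTT assay, with a stated time of 48 h (on this read-out higher numbers stand for weaker inhibition and lower numbers for stronger inhibition), and compound 3 stands within the scatter of both others, as shown by (a 1.8-fold higher number from compound 1 to compound 3 (0.25 log units; within the scatter)) and (a 1.1-fold higher number from compound 2 to compound 3 (0.02 log units; within the scatter)). Compound 4 `C=C1CCC[C@]2(C)CCC(c3cn(-c4ccc(Cl)cc4)nn3)=CC[C@@]12C` carries 4-chlorophenyl in place of 3-methoxyphenyl on an aromatic nitrogen. Within the data shown here, the remaining measured swap at that nitrogen (a 1.7-fold higher number from compound 1 to compound 2 (0.23 log units; within the scatter)) also stays within the scatter, and no 4-chlorophenyl compound has been measured. The expected step is a 1.3-fold lower number from compound 3 to compound 4 (0.10 log units; within the scatter) and so no step beyond the scatter is expected in this assay here. For compound 4 the estimated value is 580000 nM with an expected range from 320000 nM to 1000000 nM on this read-out.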

Compound 4, half-maximal inhibitory concentration: 609000 nM
For compound 4 the middle estimate is 1.1-fold (0.02 log units) below the measured one; the range from low to high includes it.
By their numbers in this assay, from the lowest: compounds 1, 4, 2 and 3 (each within the scatter of the next).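

In this assay a chloro-bearing aryl group on the aromatic nitrogen stays within the scatter of all three earlier aryl groups (a 1.2-fold lower number from compound 3 to compound 4 (0.08 log units; within the scatter)) (a 1.1-fold lower number from compound 2 to compound 4 (0.06 log units; within the scatter)) (a 1.5-fold higher number from compound 1 to compound 4 (0.17 log units; within the scatter)). A halogen therefore joins methoxy and nitro at this position, and none of the four compounds separates from the others. No measurement here offers an explanation for this flat result.

Going by these compounds, it remains open whether an amine or a carboxylic acid on the aryl ring, or a longer chain in place of the ring, would give a step beyond the scatter.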